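A few compounds are considered here, and "the series" means these few. Any claim that something is new, unique, unknown or untested is made for them only; others in the source may bear on it.

Compound 2 `ClCc1ccccc1Cn1cnc2c(Cl)ncnc21` and compound 1 `ClCc1ccccc1Cn1cnc2c(Cl)nc(Cl)nc21` share a core, and compound 3 `ClCc1cccc(Cn2cnc3ncnc(Cl)c32)c1` is built on a second core; the difference between the two cores is not broken down here. In a functional assay on SNB-75 cells (Homo sapiens) for cytotoxicity, read by sulforhodamine B assay, with a stated time of 48 h (a higher number here means a weaker inhibitor of growth, a lower number a stronger inhibitor of growth), compound 2 gives 11000 nM, and compound 1 gives 3540 nM. The change chloro in place of hydrogen on an aromatic carbon made a step of a 3.1-fold lower number from compound 2 to compound 1 (0.49 log units; beyond the scatter). Compound 3 gives 3540 nM in this assay, level with compound 1 at the digits shown. Compound 4 `ClCc1cccc(Cn2cnc3nc(Cl)nc(Cl)c32)c1` has not yet been measured; it differs from compound 3 by chloro in place of hydrogen on an aromatic carbon, the same change, made once more on the second core. Resting on the step of a 3.1-fold lower number from compound 2 to compound 1 (0.49 log units; beyond the scatter), the expected step is a 3.0-fold lower number from compound 3 to compound 4 (0.47 log units; beyond the scatter). Compound 4 is therefore estimated at 1200 nM in this assay, with a likely range from 500 nM to 3000 nM.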

Compound 4, concentration for total growth inhibition: 2290 nM
Beside the measured number, compound 4's estimate is 1.9-fold (0.28 log units) below it; measured number inside the range.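

In this assay, chloro in place of hydrogen on the second core gave a 1.5-fold lower number from compound 3 to compound 4 (0.19 log units; within the scatter), and the two steps for this change do not differ by more than the scatter allows: the same change on two cores in this assay, a 3.1-fold lower number (0.49 log units; beyond the scatter) from compound 2 to compound 1 and a 1.5-fold lower number (0.19 log units; within the scatter) from compound 3 to compound 4, 2.0-fold (0.30 log units) apart, within the scatter of two such steps. The change can therefore be carried from one core to the other without a detectable difference in its size, although the step on the second core cannot itself be told apart from the scatter. With a single pair on each core, this does not show that the effect is truly equal on both cores, and it says nothing beyond these four compounds.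

The compounds shown leave open whether another group on the aromatic carbon between two ring nitrogen atoms, such as an amine or a methoxy group, would give a step like that of chloro. They also leave open whether the two cores would treat such a group alike.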